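Methyl to ethyl: working notes on the series

A few compounds are considered here, and "the series" means these few. Any claim that something is new, unique, unknown or untested is made for them only; others in the source may bear on it.

Values so far in an ADME assay on CHO cells (Cricetulus griseus) for cytotoxicity, read by MTT assay; a lower number here means a stronger inhibitor, a higher number a weaker inhibitor:
compound 1 `Oc1cc(CCCc2ccc(F)cc2)ccc1CN1CCCCC1` gives 163000 nM
compound 2 `Cc1ccc(CCCc2ccc(CN3CCCCC3)c(O)c2)cc1` gives 4950 nM

Of these two, compound 2 has the lower number at 4950 nM. Compound 3 `CCc1ccc(CCCc2ccc(CN3CCCCC3)c(O)c2)cc1` is not yet measured. It differs from compound 2 by methyl in place of hydrogen on a saturated chain carbon bound to an aromatic carbon, or 4-methylphenyl to 4-ethylphenyl.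

Among the measured compounds shown here, only one measured step bears on this: a 33-fold lower number from compound 1 to compound 2 (1.52 log units; beyond the scatter), large and beyond the scatter, with methyl in place of fluoro on an aromatic carbon. That is a different exchange, so it guides the new one only loosely. A small move towards a lower number is expected, probably within the scatter. The expected step is a 1.4-fold lower number from compound 2 to compound 3 (0.15 log units; within the scatter). For compound 3 the estimate is 3500 nM, with an expected range from 1200 nM to 12000 nM.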

Compound 3, half-maximal inhibitory concentration: 25200 nM
The estimate for compound 3 lay 7.2-fold (0.86 log units) below the measured number; measured number above the stated range.
By their numbers in this assay, from the lowest: compound 2; then compound 3; then compound 1.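

Adding one methyl, 4-methylphenyl to 4-ethylphenyl, does not extend the earlier fall in the number in this assay; it partly reverses it, with a 5.1-fold higher number from compound 2 to compound 3 (0.71 log units; beyond the scatter). Compound 3 still keeps part of the advantage over the fluoro compound, with a 6.5-fold lower number from compound 1 to compound 3 (0.81 log units; beyond the scatter), so among these three compounds the 4-methylphenyl group gives the lowest number and a carbon group in place of fluoro does not lower it further as it grows from methyl to ethyl. No measurement available here accounts for this rise, and its origin stays unexplained.

As far as these compounds go, whether a longer chain such as propyl in place of the ethyl raises the number further remains open. The compounds shown also leave open how a methoxy group or a chlorine in place of the ethyl would compare.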